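Two Methyl Groups Added to a Hydroxycyclohexyl Ring

This account rests on a few compounds, and the source may have more. Where it says the series, first, only, none or still open, it means among the compounds named here.

Compound 1 `N#Cc1cnc(NCc2cnccc2C(F)(F)F)cc1N[C@H]1CC[C@H](O)CC1`: 350 nM
Compound 2 `COc1ncncc1CNc1cc(N[C@H]2CC[C@@H](O)CC2)c(C#N)cn1`: 800 nM

In an assay on isolated protein for inhibition of protein kinase C theta type (Homo sapiens), read by TR-FRET, with a stated time of 2 h (on this read-out lower numbers stand for stronger inhibition and higher numbers for weaker inhibition), compound 1 gives 350 nM, the lower of the two numbers measured, and compound 2 gives 800 nM, a gap beyond the usual scatter. Compound 3 `CC1(C)C[C@@H](Nc2cc(NCc3cnccc3C(F)(F)F)ncc2C#N)CC[C@@H]1O` has not been measured. It differs from compound 1 in one place: 4-hydroxy-3,3-dimethylcyclohexyl in place of 4-hydroxycyclohexyl on a nitrogen on an aromatic ring. Among the compounds with values here, no measured pair shows what this change does. In this assay the step of no change at the digits printed from compound 1 to compound 3 (within the scatter) is expected to stay within the scatter, in no clear direction. Compound 3 is therefore estimated at 350 nM, within a range from 150 nM to 900 nM.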

Compound 3, half-maximal inhibitory concentration: 120 nM
The estimate for compound 3 lay 2.9-fold (0.46 log units) above the measured number; the measured number lies below the stated range.
By their numbers in this assay, from the lowest: compound 3; then compound 1; then compound 2.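

In this assay, putting 4-hydroxy-3,3-dimethylcyclohexyl in place of 4-hydroxycyclohexyl gives a 2.9-fold lower number from compound 1 to compound 3 (0.46 log units; beyond the scatter). Within the data shown here, the earlier compounds offered no step between close neighbours, so this is the first sign that this ring can carry added carbon without losing inhibition, and that the number can even fall. No measurement here gives a reason for this shift.

Going by these compounds, whether a single methyl group, an ethyl group or a fluorine atom on the ring would move the number the same way remains open. So does whether the two methyl groups would have the same effect with the other side of compound 2.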